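Methyl on the piperidine of a pyrimidine-fused amide series

This account rests on a few compounds, and the source may have more. Where it says the series, first, only, none or still open, it means among the compounds named here.

Measured compounds:
compound 1 `O=C1CN(C2CCCC2)c2nc(Nc3ccc(N4CCCCC4)cn3)ncc2N1` — > 30000 nM
compound 2 `CC1CCN(c2ccc(Nc3ncc4c(n3)N(C3CCCC3)CC(=O)N4)nc2)CC1` — > 30000 nM
compound 3 `CN1C(=O)CN(C2CCCC2)c2nc(Nc3ccc(N4CCCCC4)cc3)ncc21` — 21200 nM

In a functional assay on MDA-MB-231 cells (Homo sapiens) for inhibition, read by MTT assay, with a stated time of 48 h (on this read-out higher numbers stand for weaker inhibition and lower numbers for stronger inhibition), compound 1 reaches only a limit of the assay, > 30000 nM. Compound 2 likewise reaches only a limit, > 30000 nM. The change between them is methyl in place of hydrogen on a saturated ring carbon, and its size is a step that the two limits leave unreadable from compound 1 to compound 2, because of the limit of > 30000 nM in this assay, at which 2 of the 3 values shown sit. Among the measured compounds shown here, compound 3 is the one member with a number, 21200 nM; how its core differs from that of compound 1 is not broken down here. Compound 4 `CC1CCN(c2ccc(Nc3ncc4c(n3)N(C3CCCC3)CC(=O)N4C)cc2)CC1` is not yet measured. It differs from compound 3 by methyl in place of hydrogen on a saturated ring carbon, the same kind of change as that from compound 1 to compound 2. Since that earlier step is not readable, the step from compound 3 to compound 4 is expected to be small, a 1.1-fold lower number from compound 3 to compound 4 (0.03 log units; within the scatter), resting on the value of compound 3, 21200 nM. Compound 4 is estimated at 20000 nM, between 8000 nM and 50000 nM.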

Compound 4, half-maximal inhibitory concentration: > 30000 nM
Compound 4: only a limit was reported; the forecaster's own chance of this, stated with the estimate: 35%; at least 1.5-fold (0.17 log units) between middle value and limit.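

In this assay, putting the methyl on the core of compound 3 gives an at least 1.4-fold higher number from compound 3 to compound 4 (0.15 log units; that floor lies within the scatter). Compound 4 reaches only a limit of the assay, > 30000 nM. This shows no gain in inhibition from 4-methylpiperidin-1-yl on this core, but it does not show that the change acts alike on both cores, since the step on the core of compound 1 cannot be read and the true size of the step on the core of compound 3 stays unknown: the limit of > 30000 nM in this assay, at which 3 of the 4 values shown sit.

The compounds shown leave open whether an amine, a carboxylic acid or a longer chain in place of the methyl would give a readable number on either core. They also leave open how large the methyl step really is on either core.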